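Methyl to pentyl on compound 3

The compounds below may be only part of what the source reports. "The series", "measured", "known", "first", "only" and "open" are said of these compounds alone.

In a toxicity assay on GES1 cells (Homo sapiens) for inhibition, read by MTT assay, with a stated time of 72 h (on this read-out lower numbers stand for stronger inhibition and higher numbers for weaker inhibition), compound 1 (`Cc1cc(N2CC[C@@H](C)[C@@H](N(C)c3ncnc4[nH]ccc34)C2)n2nc(SCc3ccc(Cl)cc3)nc2n1`) gives > 100000 nM, which is a limit of the assay. Compound 2 (`C[C@@H]1CCN(c2cc(-c3ccccc3)nc3ncnn23)C[C@@H]1N(C)c1ncnc2[nH]ccc12`) gives > 100000 nM, also a limit. Among the measured compounds shown here, compound 3 (`Cc1nc2nc(SCc3ccc(Cl)cc3)nn2c(N2CC[C@@H](C)[C@@H](N(C)c3ncnc4[nH]ccc34)C2)c1C`) gives 99200 nM, the only true number so far. The ceiling in view is the limit of > 100000 nM in this assay, at which 2 of the 3 values shown sit.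

Compound 4 (`CCCCCc1c(C)nc2nc(SCc3ccc(Cl)cc3)nn2c1N1CC[C@@H](C)[C@@H](N(C)c2ncnc3[nH]ccc23)C1`) differs from compound 3 by butyl in place of hydrogen on a saturated chain carbon bound to an aromatic carbon, which reads as methyl to pentyl.

For the measured compounds named here, one measured step bears on this change, the methyl in place of hydrogen on an aromatic carbon, seen as a number no higher from compound 1 to compound 3 (the limit leaves the size open). Its size cannot be read, and only its direction carries over, so the evidence is thin. The expected change is a 2.2-fold lower number from compound 3 to compound 4 (0.34 log units; beyond the scatter), a modest estimated move toward stronger inhibition, and this assay may still report only a limit. For compound 4 the estimated value is 45000 nM, with an expected range of 12000 nM to 100000 nM.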

Compound 4, half-maximal inhibitory concentration: > 100000 nM
Compound 4: only a limit was reported; the forecaster's own chance of this, stated with the estimate: 35%; middle value at least 2.2-fold (0.34 log units) away from the limit.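

Methyl to pentyl at this place gives a number no lower from compound 3 to compound 4 (the limit leaves the size open), so in this assay the longer chain brings no sign of stronger inhibition. Compound 4 gives > 100000 nM, which is a limit of the assay, and it joins the other compounds at the ceiling: the limit of > 100000 nM in this assay, at which 3 of the 4 values shown sit. Neither new step can be read for size, so the series shows only that a pentyl chain on this carbon leaves the read-out at the ceiling, not how far the number moves.

Going by these compounds, how far compound 1, compound 2 and compound 4 lie beyond the limit stays open. Also open, on these data alone, is whether a shorter chain such as ethyl, or an amine or a carboxylic acid at the end of the pentyl chain, would bring the number down from the ceiling.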